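The compounds below may be only part of what the source reports. "The series", "measured", "known", "first", "only" and "open" are said of these compounds alone.

In a functional assay on LOX IMVI cells (Homo sapiens) for cytotoxicity, read by MTT assay, with a stated time of 24 h (a lower number here means a stronger inhibitor, a higher number a weaker inhibitor), compound 3 (`Cc1ccc(S(=O)(=O)NCCCNc2nccc(-c3[nH]c(-c4ccccc4)nc3-c3ccc(Cl)c(O)c3)n2)cc1`) gives 6020 nM, the second highest of three numbers. Compound 2 (`O=S(=O)(NCCCNc1nccc(-c2[nH]c(-c3ccccc3)nc2-c2ccc(Cl)c(O)c2)n1)c1ccc(F)cc1`) gives 2300 nM, and compound 1 (`COc1cc(-c2nc(-c3ccccc3)[nH]c2-c2ccnc(NCCCNS(=O)(=O)c3cccc4ccccc34)n2)ccc1F`) gives 14900 nM. Compound 4 (`O=S(=O)(NCCCNc1nccc(-c2[nH]c(-c3ccccc3)nc2-c2ccc(Cl)c(O)c2)n1)c1cccc2ccccc12`) differs from compound 3 by naphthalen-1-yl in place of 4-methylphenyl on a sulfonyl sulfur, with naphthalen-1-yl in place of 4-methylphenyl on a sulfonyl sulfur. Among the measured compounds shown here, the only measured step bearing on this group is a 2.6-fold higher number from compound 2 to compound 3 (0.42 log units; beyond the scatter), a modest change that does not involve naphthalen-1-yl. Compound 1, at 14900 nM, also carries naphthalen-1-yl but differs from compound 4 elsewhere, so it offers only a weak hint of a higher number. No change beyond the scatter is therefore expected in this assay, and the estimated step is a 1.2-fold higher number from compound 3 to compound 4 (0.07 log units; within the scatter). For compound 4 the expected value is 7000 nM, with an estimated range of 2500 nM to 18000 nM.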

Compound 4, half-maximal inhibitory concentration: 7720 nM
Compound 4: middle estimate off by 1.1-fold (0.04 log units), on the low side, within the range that was stated.
By their numbers in this assay, from the lowest: compound 2; then compounds 3, 4 and 1 (each within the scatter of the next, the first and the last beyond it).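

On a sulfonyl sulfur, naphthalen-1-yl in place of 4-methylphenyl stays within the scatter in this assay, at a 1.3-fold higher number from compound 3 to compound 4 (0.11 log units; within the scatter), whereas naphthalen-1-yl in place of 4-fluorophenyl gives a 3.4-fold higher number from compound 2 to compound 4 (0.53 log units; beyond the scatter), beyond it. With naphthalen-1-yl held constant, 4-chloro-3-hydroxyphenyl in place of 4-fluoro-3-methoxyphenyl on an aromatic carbon gives a 1.9-fold lower number from compound 1 to compound 4 (0.29 log units; within the scatter), also within the scatter. No evidence is available to explain these steps. Going by these compounds, whether an amine on the sulfonyl sulfur, or a longer chain to the sulfonamide nitrogen, would give a lower number than compound 2 remains open.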